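The source may hold more compounds than are shown below. What is called first, only, known or untested is meant among the compounds shown, and "the series" means these compounds.

Measured so far:
compound 1, `Fc1ccccc1-c1cn2ccnc2c(-c2ccc3ncn(C4CCCCC4)c3c2)n1`, with 1.95 in a physicochemical assay for lipophilicity, using the shake flask method, in phosphate buffer, measured as octanol-water partition, with a stated time of 85 min, at pH 7.4; a lower number here means a more polar compound, a higher number a more lipophilic compound
compound 2, `c1csc(-c2cn3ccnc3c(-c3ccc4ncn(C5CCCCC5)c4c3)n2)c1`, with 1.38 in this assay

Compound 2 holds the lowest of the two numbers in this assay; its nearest neighbour is compound 1, whose value is higher by a number 0.57 log units lower from compound 1 to compound 2 (beyond the scatter). Compound 3, `FC(F)(F)c1cccc(-c2cn3ccnc3c(-c3ccc4ncn(C5CCCCC5)c4c3)n2)c1`, has not yet been measured. It differs from compound 2 in one place: 3-(trifluoromethyl)phenyl in place of thiophen-2-yl on an aromatic carbon. Going by the values given here, only one measured step bears on this change, the one from compound 1 to compound 2, in which the thiophen-2-yl compound came out lower by a number 0.57 log units lower from compound 1 to compound 2 (beyond the scatter). Going from thiophen-2-yl to a six-membered carbon-only ring carrying trifluoromethyl, the expectation is a rise in this assay of about a number 1.12 log units higher from compound 2 to compound 3 (beyond the scatter), taking compound 3 above compound 1. Compound 3 is therefore estimated at 2.5, with a plausible range from 1.9 to 3.1.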

Compound 3, partition coefficient: 1.72
Estimate against measurement, compound 3: 0.78 log units above, outside the stated range (below it).
By their numbers in this assay, from the lowest: compound 2; then compounds 3 and 1 (each within the scatter of the next).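

At this aromatic carbon next to the ring nitrogen, the step to 3-(trifluoromethyl)phenyl from thiophen-2-yl is a number 0.34 log units higher from compound 2 to compound 3 (beyond the scatter) in this assay and stays modest, although the entering group has more heavy atoms than the one it replaces. Against 2-fluorophenyl the same group shows a number 0.23 log units lower from compound 1 to compound 3 (within the scatter) and so cannot be told apart from it here, which leaves thiophen-2-yl as the only one of the three groups standing apart from both others. No measured evidence accompanies these numbers to explain them.

As far as these compounds go, it remains open how an unsubstituted phenyl would compare with these groups, and whether an amine or a carboxylic acid on the phenyl ring would move the number further. From the compounds shown here alone, it is also open whether trifluoromethyl would give the same reading at another place on that ring.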